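The source may hold more compounds than are shown below. What is called first, only, known or untested is meant among the compounds shown, and "the series" means these compounds.

In a physicochemical assay for solubility, in phosphate buffer, with a stated time of 18 h (on this read-out lower numbers stand for lower solubility and higher numbers for higher solubility), compound 1 (`Cc1ncc2c(N)c(C#N)c(N)nc2n1`) gives 783000 nM. Compound 2 (`CC(C)c1ncc2c(N)c(C#N)c(N)nc2n1`) gives > 1000000 nM, which is a limit of the assay. Compound 3 (`CC(C)(C)c1nc(CCCCC#N)c2c(N)c(C#N)c(N)nc2n1`) gives 16000 nM, the lowest number of the three. Compound 4 (`CC(C)(C)c1nc(-c2ccsc2)c2c(N)c(C#N)c(N)nc2n1`) carries thiophen-3-yl in place of 4-cyanobutyl on an aromatic carbon. Among the measured compounds shown here, only one measured step is available, an at least 1.2-fold higher number from compound 1 to compound 2 (0.10 log units; that floor lies within the scatter), and it exchanges different groups, so it gives no size for this change. The data therefore fix neither size nor direction, and the expectation is a tentative one. A modest fall is expected in this assay, a 2.3-fold lower number from compound 3 to compound 4 (0.36 log units; beyond the scatter). For compound 4 the estimated value is 7000 nM, with an expected range of 1500 nM to 30000 nM.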

Compound 4, solubility: 40000 nM
Compound 4: the middle estimate sits 5.7-fold (0.76 log units) below what was measured; the measured number lies above the stated range.
By their numbers in this assay, from the lowest: compound 3; then compound 4; then compound 1. At a limit, above all of these: compound 2.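

In this assay the aromatic carbon next to the ring nitrogen responds to a change of group: thiophen-3-yl in place of 4-cyanobutyl gives a 2.5-fold higher number from compound 3 to compound 4 (0.40 log units; beyond the scatter) with the tert-butyl group kept in place. This is the first step shown at this position, and it places an aromatic ring above an open chain ending in a nitrile. Nothing measured here accounts for the step. On these data alone, whether the ring's arrival or the nitrile's loss matters stays open. So does what a plain butyl chain, a phenyl ring or an amine would give at this carbon.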